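The source may report more compounds than this note shows. Statements on the series, on what has been measured and on what is new or still open speak of the compounds shown alone.

Of the compounds shown here, three have numbers so far in a functional assay on QG-56 cells (Homo sapiens) for antiproliferative activity; on this read-out lower numbers stand for stronger inhibition and higher numbers for weaker inhibition. Compound 1 `Cn1cncc1C(O)(c1ccc(C#N)cc1)c1cc2cc([N+](=O)[O-])cc(-c3ccccc3F)c2o1` gives 89.5 nM, the second highest of the three. Compound 2 `Cn1cncc1[C@@](N)(c1ccc(C#N)cc1)c1cc2cc(C#N)cc(-c3cccc(F)c3)c2o1` gives 2 nM, clearly stronger inhibition, and compound 3 `Cn1cncc1C(O)(c1ccc(C(=O)OC(C)(C)C)cc1)c1cc2cc([N+](=O)[O-])cc(-c3ccccc3)c2o1` gives 6250 nM, clearly weaker inhibition. Both gaps lie beyond the usual scatter, but each of these two compounds differs from compound 1 in more than one place, so neither gap can be tied to a single group.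

Compound 4 `Cn1cncc1C(O)(c1ccc(C#N)cc1)c1cc2cc([N+](=O)[O-])cc(-c3cccc(C#N)c3)c2o1` has not been measured. It keeps the core of compound 1 and changes one group, with 3-cyanophenyl in place of 2-fluorophenyl on an aromatic carbon. Among the compounds with values here, no measured pair isolates this swap. Compound 2 also lacks the 2-fluorophenyl group and gives 2 nM, yet compound 3 lacks it too and gives 6250 nM, so the guidance is weak. The estimated change is a 2.2-fold lower number from compound 1 to compound 4 (0.35 log units; beyond the scatter), a small expected move toward a lower number. Compound 4 is estimated at 40 nM, with an expected range from 6 nM to 250 nM.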

Compound 4, half-maximal inhibitory concentration: 22.9 nM
Beside the measured number, compound 4's estimate is 1.7-fold (0.24 log units) above it; low and high end bracket the measured number.
By their numbers in this assay, from the lowest: compound 2; then compound 4; then compound 1; then compound 3.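

In this assay, putting 3-cyanophenyl in place of 2-fluorophenyl on this aromatic carbon gives a 3.9-fold lower number from compound 1 to compound 4 (0.59 log units; beyond the scatter). Within the data shown here, this is the first pair here that differs in one place only, so this modest gain can be tied to the swap itself, and it shows that this position accepts a phenyl ring carrying a nitrile with no loss of inhibition. Nothing available here explains why the number falls.

The swap removes the fluorine, adds the nitrile and moves the substituent to another place on the phenyl ring all at once, so the compounds shown do not separate these three changes. Also open, on these data alone, is how a phenyl ring carrying an amine or a carboxylic acid would behave at this position.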